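The compounds below may be only part of what the source reports. "The series", "measured", "known", "first", "only" and "open" are said of these compounds alone.

Measured compounds in this series:
Compound 1, `CNC(=O)CC1CCc2cc(OC)c(OC)cc21`: 29%
Compound 2, `CCNC(=O)CC1CCc2cc(OC)c(OC)cc21`: 26.1%

In a functional assay on the whole organism (strain Wistar) for inhibition, with Rattus norvegicus as the target, read by paw edema, with stated times of 60 min and 3 h, at a dose of 100 mg/kg by the oral route (on this read-out higher numbers stand for more inhibition at the one dose given (going by the name of the read-out) and lower numbers for less inhibition), compound 1 gives 29% and compound 2 gives 26.1%. Within the data shown here, compound 2 holds the lower of the two numbers, but the only step measured, a number 2.9 percentage points lower from compound 1 to compound 2 (within the scatter), lies within the scatter, so the two compounds cannot be placed in order.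

Compound 3, `COc1cc2c(cc1OC)C(CC(=O)N1CCNCC1)CC2`, differs from compound 2 by piperazin-1-yl in place of ethylamino on a carbonyl carbon. Among the measured compounds shown here, no measured step exchanges the amide substituent for a ring; the single step available, a number 2.9 percentage points lower from compound 1 to compound 2 (within the scatter), concerns methyl in place of hydrogen on the chain carbon and was within the scatter, so it bears on the new change only loosely. On that slim basis the step to compound 3 is expected to be small in either direction, estimated as a number 1.1 percentage points lower from compound 2 to compound 3 (within the scatter). Compound 3 is therefore expected at 25%, with a range from 10% to 40%.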

Compound 3, a percentage reported as inhibition, in the whole organism at one dose (the size of the read-out at that dose, not a potency): 42%
Estimate against measurement, compound 3: 17 percentage points below; the measured number lies above the stated range.
By their numbers in this assay, from the lowest: compounds 2 and 1 (each within the scatter of the next); then compound 3.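

At the carbonyl carbon, the amide substituent is the one place among the compounds shown where a change moves the number in this assay beyond the scatter: piperazin-1-yl in place of ethylamino gives a number 15.9 percentage points higher from compound 2 to compound 3 (beyond the scatter) and piperazin-1-yl in place of methylamino gives a number 13 percentage points higher from compound 1 to compound 3 (beyond the scatter). Methylamino and ethylamino stay within the scatter of each other, while the six-membered ring stands apart from both, so this position accepts the larger ring with no loss of inhibition at the one dose given. No evidence on the origin of this rise is available.

The compounds shown leave open whether the ring alone or its second ring nitrogen goes with the higher number; piperidin-1-yl and morpholin-4-yl on the same carbonyl carbon would separate the two. Also open, going by these compounds, is whether 4-methylpiperazin-1-yl keeps the rise.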